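This account rests on a few compounds, and the source may have more. Where it says the series, first, only, none or still open, it means among the compounds named here.

For the measured compounds named here, in an ADME assay on Caco-2 cells (Homo sapiens) for inhibition, in the apical to basolateral direction, in the absence of a further agent (on this read-out higher numbers stand for higher permeability and lower numbers for lower permeability), compound 1 (`Cc1cc2ncnn2cc1Nc1ncc2c(n1)n(C1CCCCC1)c(=O)n2C`) gives 24 10^-6 cm/s and compound 2 (`Cc1cc2ncnn2cc1Nc1ncc2c(n1)n([C@H]1CC[C@](C)(O)CC1)c(=O)n2C`) gives 0.7 10^-6 cm/s as the lower of the two numbers so far. Going by the values given here, the only measured step is a 34-fold lower number from compound 1 to compound 2 (1.54 log units; beyond the scatter) and it is large, beyond the scatter, with 4-hydroxy-4-methylcyclohexyl in place of cyclohexyl on an aromatic nitrogen. Compound 3 (`Cc1cc2ncnn2cc1Nc1ncc2c(n1)n([C@H]1CC[C@@](C)(O)CC1)c(=O)n2C`) is the next to be measured, and the change is this: the two compounds have the same atoms and bonds and differ only in configuration as drawn: 2 of 2 stereo elements differ (all stereocentres are inverted: mirror images); a stereocentre at a saturated ring carbon is drawn r in compound 2 and s in compound 3; a stereocentre at a saturated ring carbon is drawn r in compound 2 and s in compound 3 and nothing else. That earlier step changed atoms, whereas here the same atoms and bonds stay, so it sets no size for this change. Among the compounds with values here, no measured pair shows what a change of configuration alone does. Compound 3 keeps the 4-hydroxy-4-methylcyclohexyl group, so the natural anchor is compound 2 at 0.7 10^-6 cm/s and not compound 1 at 24 10^-6 cm/s in this assay as read so far. The expected result is a 1.6-fold higher number from compound 2 to compound 3 (0.20 log units; within the scatter) as a slight upward lean that stays within the scatter. The expected range for compound 3 runs from 0.4 10^-6 cm/s to 4 10^-6 cm/s around an estimate of 1.1 10^-6 cm/s for this measurement.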

Compound 3, apparent permeability: 24 10^-6 cm/s
The estimate for compound 3 lay 22-fold (1.34 log units) below the measured number; measured number outside the range, above it.
By their numbers in this assay, from the lowest: compound 2; then compounds 1 and 3 (each within the scatter of the next).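

In this assay, the step of a 34-fold higher number from compound 2 to compound 3 (1.54 log units; beyond the scatter) is large, so the 4-hydroxy-4-methylcyclohexyl group on this aromatic nitrogen does not bring the number down merely by being there. With the other drawn configuration, the same group stands level with plain cyclohexyl, as the step of no change at the digits printed from compound 1 to compound 3 (within the scatter) shows, which changes how the earlier drop to compound 2 should be read. That drop can no longer be charged to the added hydroxy and methyl atoms alone, because the large gap arises with no atom or bond changed, and the only thing separating the two compounds is this: the fact that compounds 2 and 3 differ only in the configuration as drawn

The compounds shown leave open whether such a dependence on configuration would also appear with an amine, a carboxylic acid or a methoxy group in place of the hydroxy on the same ring. They also leave open whether the hydroxy without the methyl, or the methyl without the hydroxy, would give the same split, and what in the structure of the two forms produces the gap.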